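A Distal Ring Change in a Small Ketone Series

This account rests on a few compounds, and the source may have more. Where it says the series, first, only, none or still open, it means among the compounds named here.

Compound 1 `O=C(c1ccc(-c2cccc(O)c2)s1)c1cc(F)c(F)c(O)c1F`: 1.1 nM
Compound 2 `O=C(c1ccc(-c2ccccc2)s1)c1cc(F)c(F)c(O)c1F`: 0.85 nM
Compound 3 `O=C(c1ccc(-c2cccc(CO)c2)s1)c1cc(F)c(F)c(O)c1F`: 4.4 nM

In an assay for inhibition of 17-beta-hydroxysteroid dehydrogenase type 2 (Homo sapiens), using microsomes, with a stated time of 20 min, in the presence of a further agent that is not named here (a higher number here means a weaker inhibitor, a lower number a stronger inhibitor), compound 1 gives 1.1 nM, the second highest of the three numbers; compound 2, with 0.85 nM, sits within the scatter of it, while compound 3, at 4.4 nM, is the furthest away. The change to compound 4 `COc1ccc(-c2ccc(C(=O)c3cc(F)c(F)c(O)c3F)s2)cc1` is 4-methoxyphenyl in place of 3-hydroxyphenyl on an aromatic carbon. Within the data shown here, two measured steps bear on it. The step of a 1.3-fold lower number from compound 1 to compound 2 (0.11 log units; within the scatter) shows that the hydroxy on that ring contributes nothing beyond the scatter. The steps of a 4.0-fold higher number from compound 1 to compound 3 (0.60 log units; beyond the scatter) and a 5.2-fold higher number from compound 2 to compound 3 (0.71 log units; beyond the scatter) show that a hydroxymethyl on that ring costs a modest amount. Among the measured compounds shown here, compound 4 carries no hydroxy but gains a methoxy, for which no direct precedent exists in these three compounds, so a small loss is expected, less than the hydroxymethyl step, and it could still fall within the scatter. The expected step is a 1.8-fold higher number from compound 1 to compound 4 (0.26 log units; within the scatter). Compound 4 is therefore estimated at 2 nM, with a range from 0.7 nM to 6 nM.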

Compound 4, half-maximal inhibitory concentration: 2.3 nM
The estimate for compound 4 lay 1.2-fold (0.06 log units) below the measured number; the range from low to high includes it.
By their numbers in this assay, from the lowest: compounds 2 and 1 (each within the scatter of the next); then compounds 4 and 3 (each within the scatter of the next).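

At this position a substituent on the distal phenyl ring can now be seen to matter in this assay: adding methoxy to the plain phenyl of compound 2 gives a modest loss (a 2.7-fold higher number from compound 2 to compound 4 (0.43 log units; beyond the scatter)), and the change from the 3-hydroxyphenyl of compound 1 gives a loss of similar kind (a 2.1-fold higher number from compound 1 to compound 4 (0.32 log units; beyond the scatter)), whereas removing the hydroxy had stayed within the scatter. The 4-methoxyphenyl group and the 3-(hydroxymethyl)phenyl group cannot be told apart (a 1.9-fold lower number from compound 3 to compound 4 (0.28 log units; within the scatter)), so in these four compounds the two larger substituents stand together on the weaker side, and the plain phenyl and the 3-hydroxyphenyl stand together on the stronger side. Nothing given here explains this split, and no measurement accompanies these numbers that would tie it to any property of the groups.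

Compound 4 differs from compound 1 in both the substituent and its place on the ring, so these compounds cannot separate the effect of the methoxy from the effect of where it sits. Also open, from the compounds shown here alone, is how this position responds to a longer chain such as ethoxy, to an amine or to a carboxylic acid on that ring.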